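Stereoisomer of compound 1 in mouse microsomes

A few compounds are considered here, and "the series" means these few. Any claim that something is new, unique, unknown or untested is made for them only; others in the source may bear on it.

The series shares one core. Going by the values given here, compound 1 `CNC(=O)Nc1ccc(-c2nc(N3CC4CCC(C3)O4)c3cnn([C@H]4CC[C@@H](OC)CC4)c3n2)cc1` is the only compound with a number in an in vitro ADME assay on microsomes (Mus musculus) for metabolic stability (a higher number here means that the compound lasts longer, a lower number that the compound disappears faster), where compound 1 gives 0.283 h. For compound 2 `O=C(Nc1ccc(-c2nc(N3CC4CCC(C3)O4)c3cnn(C4CCC5(CC4)OCCO5)c3n2)cc1)Nc1cccnc1` the value in this assay is a limit, > 0.5 h. For compound 3 `CNC(=O)Nc1ccc(-c2nc(N3CC4CCC(C3)O4)c3cnn([C@H]4CC[C@@H](O)CC4)c3n2)cc1` the value in this assay is likewise a limit, > 0.5 h; two of the three values sit on (the limit of > 0.5 h in this assay, at which 2 of the 3 values shown sit). Among the compounds with values here, the one measured step is an at least 1.7-fold higher number from compound 1 to compound 3 (0.24 log units; that floor lies within the scatter), a change of the group on oxygen. Compound 4 `CNC(=O)Nc1ccc(-c2nc(N3CC4CCC(C3)O4)c3cnn([C@H]4CC[C@H](OC)CC4)c3n2)cc1` differs from compound 1 only in drawn configuration: the two compounds have the same atoms and bonds; at least one stereo element is drawn with a configuration in one of them and without one in the other: 2 of 4 stereo elements differ; a stereocentre at a saturated ring carbon is drawn s in compound 1 and r in compound 4; a stereocentre at a saturated ring carbon is drawn s in compound 1 and r in compound 4. Within the data shown here, no measured step changes a stereocentre alone, so the step to compound 3 does not bear on this one, and no step beyond the scatter is expected. Compound 4 is therefore expected to give 0.3 h (range 0.15 h to 0.6 h) in this assay. The expected step of a 1.1-fold higher number from compound 1 to compound 4 (0.03 log units; within the scatter) is within the scatter.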

Compound 4, half-life: > 0.5 h
Compound 4 gave a limit, no number; the forecaster's own chance of this, stated with the estimate: 25%; middle value at least 1.6-fold (0.22 log units) from the limit.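

With the 4-methoxycyclohexyl group kept, a change in drawn configuration alone gives an at least 1.7-fold higher number from compound 1 to compound 4 (0.24 log units; that floor lies within the scatter) in this assay, and this comparison carries one reservation: the fact that one of compounds 1 and 4 is drawn with a defined configuration and the other without, at the place where they differ. Compound 4 gives > 0.5 h, which is a limit and not a number, and it joins the compounds at that ceiling: the limit of > 0.5 h in this assay, at which 3 of the 4 values shown sit. The remaining step cannot be read, as both of its values are limits.

Open, going by these compounds, are the distance of compound 4 from that limit and the effect of each drawn configuration taken singly. Also open, on these data alone, is how a 4-aminocyclohexyl group on the aromatic nitrogen would read in this assay.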